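The compounds below may be only part of what the source reports. "The series", "measured", "known", "first", "only" and "open" are said of these compounds alone.

Measured compounds in a functional assay on U-87MG ATCC cells for cytotoxicity against U-87 MG (Homo sapiens), read by MTT assay, with a stated time of 72 h; on this read-out higher numbers stand for weaker inhibition and lower numbers for stronger inhibition:
compound 1 `COc1ncc(-c2ccc3nc(NC(=O)NCC(=O)N4CCCCC4)nn3c2)cc1NS(=O)(=O)c1ccc(F)cc1` gives 740 nM;
compound 2 `COc1ncc(-c2ccc3nc(NC(=O)N4CCCC4)nn3c2)cc1NS(=O)(=O)c1ccc(F)cc1` gives 1690 nM;
compound 3 `COc1ncc(-c2ccc3nc(NC(=O)NCCN4CCCC4)nn3c2)cc1NS(=O)(=O)c1ccc(F)cc1` gives 1120 nM.

Compound 2 has the highest number of the three: its nearest neighbour is compound 3 (a 1.5-fold lower number from compound 2 to compound 3 (0.18 log units; within the scatter)), its furthest compound 1 (a 2.3-fold higher number from compound 1 to compound 2 (0.36 log units; beyond the scatter)).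

Compound 4 `CCCNC(=O)Nc1nc2ccc(-c3cnc(OC)c(NS(=O)(=O)c4ccc(F)cc4)c3)cn2n1` differs from compound 2 in one place: propylamino in place of pyrrolidin-1-yl on a carbonyl carbon. Both measured steps that open the pyrrolidin-1-yl urea into an amino-linked chain bear on this, a 2.3-fold higher number from compound 1 to compound 2 (0.36 log units; beyond the scatter) read in reverse and a 1.5-fold lower number from compound 2 to compound 3 (0.18 log units; within the scatter), each pointing to a lower number. The propylamino chain is shorter than either measured chain, so a small shift is expected in this assay, a 1.4-fold lower number from compound 2 to compound 4 (0.15 log units; within the scatter), at the edge of the scatter. Compound 4 is expected at 1200 nM, within 600 nM to 2500 nM.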

Compound 4, half-maximal inhibitory concentration: 420 nM
Beside the measured number, compound 4's estimate is 2.9-fold (0.46 log units) above it, outside the stated range (below it).
By their numbers in this assay, from the lowest: compounds 4, 1, 3 and 2 (each within the scatter of the next, the first and the last beyond it).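

In this assay, among the compounds shown here, propylamino on the carbonyl carbon gives a 4.0-fold lower number from compound 2 to compound 4 (0.60 log units; beyond the scatter), a larger step than any among the earlier compounds, so replacing the pyrrolidin-1-yl ring at this position counts for more than those compounds showed. The plain chain also compares well with the chain ending in pyrrolidin-1-yl, with a 2.7-fold lower number from compound 3 to compound 4 (0.43 log units; beyond the scatter), while a 1.8-fold lower number from compound 1 to compound 4 (0.25 log units; within the scatter) leaves it level with the chain bearing (piperidin-1-yl)carbonyl.

From the compounds shown here alone, whether the lower number follows the hydrogen-bond donor that enters or the ring that leaves stays open, and methyl(propyl)amino, which has neither, would separate the two. No supporting data bear on the cause of these steps.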